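Trimming the side chain of compound 1

The compounds below may be only part of what the source reports. "The series", "measured", "known", "first", "only" and "open" are said of these compounds alone.

Values so far in a physicochemical assay for solubility, measured as kinetic solubility (a higher number here means a more soluble compound, a lower number a less soluble compound), are these
- compound 1 `Cc1cc(C)c(CN2CCc3c(Cl)cc([C@H](CO)[C@H]4CCOC4)c(Cl)c3C2=O)c(=O)[nH]1` gives 570000 nM
- compound 2 `COC(c1cc(Cl)c2c(c1Cl)C(=O)N(Cc1c(C)cc(C)[nH]c1=O)CC2)C1CCOC1` gives 415000 nM; 457000 nM; 439000 nM; 436000 nM (4 entries)
- compound 3 `COC(c1cc(Cl)c2c(c1Cl)C(=O)N(Cc1c(C)cc(C)[nH]c1=O)CC2)C1CCS(=O)(=O)CC1` gives 373000 nM; 415000 nM (2 entries)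

Compound 1 has a single reading, whereas compound 2 and compound 3 have repeated readings. All three sit within the usual scatter of one another, so compound 1 stands level with the other two.

Compound 4 `Cc1cc(C)c(CN2CCc3c(Cl)cc([C@H](C)CO)c(Cl)c3C2=O)c(=O)[nH]1` has not yet been measured. Its difference from compound 1 is this a group of 4 heavy atoms (3 carbon, 1 oxygen; no ring) in place of a group of 8 heavy atoms (6 carbon, 2 oxygen; one five-membered non-aromatic ring with 1 hetero atom), on an aromatic carbon and it puts a 1-(hydroxymethyl)ethyl group on the aromatic carbon in place of the larger group.

In this assay no step beyond the scatter is expected in either direction. Compound 2 at 415000 nM; 457000 nM; 439000 nM; 436000 nM (4 entries) and compound 3 at 373000 nM; 415000 nM (2 entries) carry other groups on that same carbon, and both stay within the scatter of compound 1 at 570000 nM on the numbers shown. The expected step of a 1.2-fold lower number from compound 1 to compound 4 (0.07 log units; within the scatter) is therefore small. The estimate for compound 4 is 480000 nM with 270000 nM to 800000 nM as its expected range.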

Compound 4, solubility: 131000 nM
Beside the measured number, compound 4's estimate is 3.7-fold (0.56 log units) above it, and the stated range ends above it.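

In this assay, going by these compounds alone, the exchange of the larger ring-bearing group for 1-(hydroxymethyl)ethyl on this aromatic carbon gives a 4.4-fold lower number from compound 1 to compound 4 (0.64 log units; beyond the scatter) and is the only step at this position that can be read. Within the data shown here, it shows that the number is not indifferent to the group on this carbon, something the earlier compounds did not reveal, as they carry other groups there and stand level with one another. The step rests on a single reading each of compound 1 and compound 4, while repeated entries of a close relative lie near one another: the several entries of compound 2 in this assay, 415000 nM; 457000 nM; 439000 nM; 436000 nM (4 entries)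

The compounds shown leave open whether the lower number goes with the loss of the five-membered ring or with the smaller size of the group as a whole. They also do not tell how an amine or a carboxylic acid on this carbon would read in this assay.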